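Thiosemicarbazone series: cytotoxicity, from compound 3 to compound 4

The compounds below may be only part of what the source reports. "The series", "measured", "known", "first", "only" and "open" are said of these compounds alone.

Values in a functional assay on PCO3 cells (Homo sapiens) for cytotoxicity, read by sulforhodamine B assay; a lower number here means a stronger inhibitor of growth, a higher number a weaker inhibitor of growth:
compound 1 `CC1=CC[C@@H]([C@@](C)(O)CCCC(C)(C)NC(=S)N/N=C\c2ccccc2)CC1`: 8470 nM
compound 2 `COc1ccc(/C=N\NC(=S)NC(C)(C)CCC[C@](C)(O)[C@@H]2CC=C(C)CC2)cc1`: 7660 nM
compound 3 `CC1=CC[C@@H]([C@@](C)(O)CCCC(C)(C)NC(=S)N/N=C\c2ccccc2Cl)CC1`: 18800 nM

Compound 3 gives the highest number of the three, with a 2.2-fold higher number from compound 1 to compound 3 (0.35 log units; beyond the scatter) and a 2.5-fold higher number from compound 2 to compound 3 (0.39 log units; beyond the scatter); the pair compound 1 and compound 2 sits within the scatter, a 1.1-fold lower number from compound 1 to compound 2 (0.04 log units; within the scatter).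

Compound 4 `CC1=CC[C@@H]([C@@](C)(O)CCCC(C)(C)NC(=S)N/N=C(/C)c2ccccc2)CC1` differs from compound 3 by a group of 9 heavy atoms (8 carbon, 1 nitrogen; one six-membered aromatic ring of carbon only) in place of a group of 9 heavy atoms (7 carbon, 1 nitrogen, 1 chlorine; one six-membered aromatic ring of carbon only), on an amide-type nitrogen. The measured step that bears on this is a 2.2-fold higher number from compound 1 to compound 3 (0.35 log units; beyond the scatter): the chloro that entered there is the group that leaves here, so the expectation is a return towards compound 1. Among the measured compounds shown here, the methyl that enters on the carbon double-bonded to nitrogen has no measured counterpart in this set, which widens the range but gives no direction. The expected step in this assay is therefore a modest fall, a 2.1-fold lower number from compound 3 to compound 4 (0.32 log units; beyond the scatter). For compound 4 the estimate in this assay is 9000 nM, with a range from 4500 nM to 18000 nM.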

Compound 4, concentration for 50% growth inhibition: 20000 nM
Beside the measured number, compound 4's estimate is 2.2-fold (0.35 log units) below it; measured number outside the range, above it.
By their numbers in this assay, from the lowest: compounds 2 and 1 (each within the scatter of the next); then compounds 3 and 4 (each within the scatter of the next).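

In this assay, among the compounds shown here, the methyl on the carbon double-bonded to nitrogen is the first change at this carbon, and it carries weight with the aromatic ring left bare: a 2.4-fold higher number from compound 1 to compound 4 (0.37 log units; beyond the scatter), and likewise a 2.6-fold higher number from compound 2 to compound 4 (0.42 log units; beyond the scatter). Compound 3 and compound 4 then sit together, a 1.1-fold higher number from compound 3 to compound 4 (0.03 log units; within the scatter), so the chloro on the aromatic ring and this methyl, two changes at different places on the group on the amide-type nitrogen, each lead away from compound 1 to the same level. No measurement shown here accounts for either step.

From the compounds shown here alone, it remains open whether the chloro and the methyl together would move the number further than either alone. Also open, going by these compounds, is how an ethyl or cyclopropyl on that same carbon would read in this assay.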